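Hydroxy for methoxy on a weakly cytotoxic pyrazole series

This account rests on a few compounds, and the source may have more. Where it says the series, first, only, none or still open, it means among the compounds named here.

Of the compounds shown here, three have been tested in a functional assay on OVCAR-5 cells (Homo sapiens) for inhibition, read by sulforhodamine B assay, with a stated time of 48 h; on this read-out lower numbers stand for higher toxicity in this test and higher numbers for lower toxicity in this test. Compound 1 `COc1cc(C)cc(-c2nn(CC#N)cc2-c2ccc(-c3cccc(C(C)=O)c3)nc2)c1` sits at the assay limit, returning > 100000 nM rather than a number. Going by the values given here, compound 2 `Cc1cc(O)cc(-c2nn(CC#N)cc2-c2ccnc(-c3ccc(Oc4ccccc4)cc3)c2)c1` is the one member that gives a measured concentration, with 48300 nM. Compound 3 `COc1cc(C)cc(-c2nn(CC#N)cc2-c2ccnc(-c3ccc(N(C)C)cc3)c2)c1` also sits at the limit, giving > 100000 nM. Thus compound 3 stands among the two of three values that are limits rather than numbers, as summarised by the limit of > 100000 nM in this assay, at which 2 of the 3 values shown sit, and no step between measured compounds of this set can be computed.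

Compound 4 `Cc1cc(O)cc(-c2nn(CC#N)cc2-c2ccnc(-c3ccc(N(C)C)cc3)c2)c1` is the next compound to be measured. It differs from compound 3 by hydrogen in place of methyl on an oxygen on an aromatic ring, so that the methoxy on the aryl ring of compound 3 becomes a hydroxy. Since compound 3 returned only a limit, no size of step can be read from the shown data; compound 2, which carries the same hydroxy group, yields a number, but it also differs at a second position, so the two values show only that a hydroxy analogue can fall inside the measurable range. The expected step from compound 3 to compound 4 is an at least 1.2-fold lower number from compound 3 to compound 4 (0.09 log units; that floor lies within the scatter), which is taken as modest and not clearly beyond the scatter. Compound 4 is therefore estimated at 80000 nM, in a range from 30000 nM to 200000 nM, with a real chance that the assay again reports only a limit.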

Compound 4, concentration lethal to 50% of the cells: > 100000 nM
Compound 4: only a limit was reported; the forecaster's own chance of this, stated with the estimate: 50%; at least 1.2-fold (0.09 log units) between middle value and limit.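

In this assay compound 4 gives > 100000 nM, which is a limit of the assay and not a number. Methoxy to hydroxy on the aromatic ring therefore leaves the dimethylamino compound at the limit, the step between the two limits cannot be read, and the hydroxy group alone is not enough to bring this compound into the measurable range. With the hydroxy group held constant, dimethylamino in place of phenoxy on an aromatic carbon gives an at least 2.0-fold higher number from compound 2 to compound 4 (0.31 log units; beyond the scatter), which links the only measured concentration in the set to the change at the phenoxy position rather than to the hydroxy group by itself.

Going by these compounds alone, how much methoxy to hydroxy changes the read-out remains unknown, since no pair with that change has two measured numbers, and most of the series now rests on a single ceiling: the limit of > 100000 nM in this assay, at which 3 of the 4 values shown sit. Also open, on these data alone, is whether an ethoxy group or a longer chain on that oxygen, or an amine or a carboxylic acid in place of the dimethylamino group, would give a measured concentration.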